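Trifluoromethyl for methyl: expectation for compound 4

The compounds below may be only part of what the source reports. "The series", "measured", "known", "first", "only" and "open" are said of these compounds alone.

In a functional assay on A549 cells (Homo sapiens) for antiproliferative activity, read by MTT assay, with a stated time of 24 h (a lower number here means a stronger inhibitor, a higher number a weaker inhibitor), compound 1 (`Cc1ccc(-c2nn(-c3ccccc3)cc2-c2nc3ccccc3n2S(=O)(=O)c2ccc(C)cc2)cc1`) gives 460 nM, and compound 2 (`Cc1ccc(-c2nn(-c3ccccc3)cc2-c2nc3ccccc3n2S(=O)(=O)c2cc(C)ccc2C)cc1`) gives 270 nM. These two cannot be separated, with a 1.7-fold lower number from compound 1 to compound 2 (0.23 log units; within the scatter). Compound 3 (`Cc1ccc(-c2nn(-c3ccccc3)cc2-c2nc3ccccc3n2S(=O)(=O)c2ccc(Br)cc2)cc1`) gives 1860 nM, so compound 2 holds the lowest of the three numbers only by its clear gap to compound 3, a 6.9-fold higher number from compound 2 to compound 3 (0.84 log units; beyond the scatter).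

Compound 4 (`Cc1ccc(C)c(S(=O)(=O)n2c(-c3cn(-c4ccccc4)nc3-c3ccc(C(F)(F)F)cc3)nc3ccccc32)c1`) differs from compound 2 at one place: trifluoromethyl in place of methyl on an aromatic carbon. This change turns 4-methylphenyl into 4-(trifluoromethyl)phenyl.

For the measured compounds named here, no measured step covers this carbon, since all three concern the group on the sulfonyl sulfur. The nearest guide is therefore indirect. Replacing methyl on an aromatic carbon with bromo gave a 4.0-fold higher number from compound 1 to compound 3 (0.61 log units; beyond the scatter), a modest rise in the number, and compound 3 is the only case of such a replacement. That single step, at another place in the molecule, supports a cautious expectation of a small rise in the number, possibly none beyond the scatter. The expected step is a 1.8-fold higher number from compound 2 to compound 4 (0.25 log units; within the scatter). For compound 4 the estimated value is 480 nM, with an expected range of 170 nM to 1400 nM.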

Compound 4, half-maximal inhibitory concentration: 150 nM
Compound 4: middle estimate off by 3.2-fold (0.51 log units), on the high side, and the stated range ends above it.
By their numbers in this assay, from the lowest: compounds 4, 2 and 1 (each within the scatter of the next, the first and the last beyond it); then compound 3.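

In this assay, for the compounds shown here, trifluoromethyl in place of methyl on this aromatic carbon gives a 1.8-fold lower number from compound 2 to compound 4 (0.26 log units; within the scatter) and so leaves compounds 2 and 4 inseparable, which is the first direct reading at this carbon, since the earlier compounds all carry methyl there and differ only in the group on the sulfonyl sulfur. Going from one heavy atom to four at this place, para to a large group, therefore produces no step beyond the scatter, whereas the replacement of methyl by bromo on the group on the sulfonyl sulfur gave a 4.0-fold higher number from compound 1 to compound 3 (0.61 log units; beyond the scatter) and does not carry over as a guide to this carbon. Nothing on hand explains why this change leaves the number within the scatter.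

As far as these compounds go, whether an amine, a carboxylic acid or a longer chain on this carbon would also stay within the scatter of compound 2 remains open. Also open, from the compounds shown here alone, is whether trifluoromethyl here would read the same with 4-methylphenyl or 4-bromophenyl on the sulfonyl sulfur, as this single pair carries 2,5-dimethylphenyl there.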